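Solubility of a trifluoromethyl analogue of compound 1

A few compounds are considered here, and "the series" means these few. Any claim that something is new, unique, unknown or untested is made for them only; others in the source may bear on it.

Measured compounds:
compound 1 `CNC(=O)c1cc(Oc2ccc3nc(Nc4ccccc4)ncc3c2)ccn1`: < 1000 nM
compound 2 `CNC(=O)c1cc(Oc2ccc3nc(Nc4cccc(C(C)C)c4)ncc3c2)ccn1`: < 1000 nM

In a physicochemical assay for solubility, at pH 7 (on this read-out higher numbers stand for higher solubility and lower numbers for lower solubility), compound 1 gives < 1000 nM, and this is a limit of the assay rather than a number. Compound 2 gives < 1000 nM in this assay, and this too is a limit. Within the data shown here, because the limit of < 1000 nM in this assay, at which 2 of the 2 values shown sit, holds both values, the step that the two limits leave unreadable from compound 1 to compound 2 cannot be sized; it is the only measured step, and it concerns an isopropyl in place of hydrogen on an aromatic carbon.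

Compound 3 `CNC(=O)c1cc(Oc2ccc3nc(Nc4ccc(C(F)(F)F)cc4)ncc3c2)ccn1` has not yet been measured in this assay. It differs from compound 1 by trifluoromethyl in place of hydrogen on an aromatic carbon. The step from compound 1 to compound 2 is the only one that bears on this change, and it gives neither a size nor a direction, so no step beyond the scatter can be expected on that evidence. With compound 1 at a limit, compound 3 is expected to sit near that same limit, so the expected step is a step that the limit leaves unreadable from compound 1 to compound 3. Compound 3 is estimated at 500 nM, with a range from 100 nM to 1500 nM.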

Compound 3, solubility: < 1000 nM
Compound 3 gave a limit, no number; the forecaster's own chance of this, stated with the estimate: 75%; the middle value lies beyond the limit too.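

Compound 3, like compound 1 and compound 2, gives a limit rather than a number, so no step among these three compounds can be read in this assay: the limit of < 1000 nM in this assay, at which 3 of the 3 values shown sit.

The compounds shown leave open how far the true solubility of each lies from that limit, and whether adding trifluoromethyl or isopropyl changes it at all.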